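The compounds below may be only part of what the source reports. "The series", "measured", "known", "first", "only" and "open" are said of these compounds alone.

The measured compounds and their numbers:

Compound 1 `CCCCc1cc(C(C)=O)c(O)cc1OCCCCC#N` — 41%
Compound 2 `CSCc1cc(C(C)=O)c(O)cc1OCCCCCCC#N` — 97%
Compound 3 `COCc1cc(C(C)=O)c(O)cc1OCCCCCCC#N` — 47%

In an assay on isolated protein for inhibition of leukotriene B4 receptor 1 (Homo sapiens), tested at 10 uM (a lower number here means less inhibition, a higher number more inhibition at the concentration tested (going by the name of the read-out)), compound 1 gives 41%, the lowest of the three numbers. Compound 3 stands nearest to it, with a value within the scatter of compound 1, while compound 2 stands furthest, with a value beyond the scatter above compound 1. Among the compounds with values here, the one step that can be drawn between measured compounds is a number 50 percentage points lower from compound 2 to compound 3 (beyond the scatter), a large drop.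

Compound 4 `CC(=O)c1cc(C=O)c(OCCCCC#N)cc1O` has not yet been measured. It differs from compound 1 as follows: formyl in place of butyl on an aromatic carbon. Within the data shown here, no measured step bears on this change; the only step available concerns methoxy in place of methylsulfanyl on a saturated chain carbon bound to an aromatic carbon, a different group at a different place, so it offers no guide to the size or direction of the step from compound 1 to compound 4. With nothing to rest on beyond the value of compound 1 itself, the expectation is a step of about a number 6 percentage points lower from compound 1 to compound 4 (within the scatter) in this assay, which would be within the scatter. Compound 4 is therefore estimated at 35%, expected to lie between 10% and 65%.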

Compound 4, a percentage reported as inhibition, at one concentration (the size of the read-out at that concentration, not a potency): 6%
Compound 4: the middle estimate sits 29 percentage points above what was measured; the measured number lies below the stated range.
By their numbers in this assay, from the lowest: compound 4; then compounds 1 and 3 (each within the scatter of the next); then compound 2.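

In this assay, formyl in place of butyl on the aromatic carbon ortho to a 4-cyanobutoxy group and para to a hydroxy group gives a number 35 percentage points lower from compound 1 to compound 4 (beyond the scatter). The earlier step concerned only a swap on a saturated chain carbon bound to the aromatic carbon, whereas this one shows that the number also responds strongly when the group bound directly to this aromatic carbon is exchanged. Nothing given here accounts for the drop.

As far as these compounds go, what remains open is whether the loss of butyl or the entry of formyl drives the step, a question that a methyl, a hydroxymethyl or an amine at this position could help to settle. From the compounds shown here alone, it is also open whether formyl would give a step of similar size alongside a longer nitrile-ending chain than the 4-cyanobutoxy group.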